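Working notes: from compound 3 to compound 4

The compounds below may be only part of what the source reports. "The series", "measured", "known", "first", "only" and "open" are said of these compounds alone.

Measured so far in a functional assay on HT-29 cells (Homo sapiens) for antiproliferative activity, read by sulforhodamine B assay, with a stated time of 48 h; a higher number here means a weaker inhibitor, a lower number a stronger inhibitor:
compound 1, `COc1ccccc1OS(=O)(=O)c1ccc(N2CCN(C)C2=O)cc1`: 26000 nM
compound 2, `CCCN1CCN(c2ccc(S(=O)(=O)Oc3ccccc3OC)cc2)C1=O`: > 100000 nM
compound 3, `CCCCN1CCN(c2ccc(S(=O)(=O)Oc3ccccc3OC)cc2)C1=O`: > 100000 nM

For the measured compounds named here, compound 1 is the only member with a number in this assay. For compound 2 the read-out is a limit only, > 100000 nM. For compound 3 the read-out is likewise a limit only, > 100000 nM. Compound 3 therefore stands where two of the three values sit, at the limit described by the limit of > 100000 nM in this assay, at which 2 of the 3 values shown sit, and cannot be placed against compound 2 since a step that the two limits leave unreadable from compound 2 to compound 3. The readable steps are an at least 3.8-fold higher number from compound 1 to compound 2 (0.58 log units; beyond the scatter) and an at least 3.8-fold higher number from compound 1 to compound 3 (0.58 log units; beyond the scatter); both concern the chain on the ring nitrogen, not the aryl part of the molecule.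

Compound 4, `CCCCN1CCN(c2ccc(S(=O)(=O)Oc3ccc(F)c(F)c3)cc2)C1=O`, differs from compound 3 at the other end: 3,4-difluorophenyl in place of 2-methoxyphenyl on an oxygen. Going by the values given here, no measured step touches this position, so none of the three steps bears on it, and no direction can be read for this assay. The working expectation is that compound 4 stays near the limit where compound 3 stands. Compound 4 is estimated at 100000 nM, with a range from 20000 nM to 400000 nM. The step of a number no higher from compound 3 to compound 4 (the limit leaves the size open) is expected to be within what a limit-bound starting value allows.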

Compound 4, half-maximal inhibitory concentration: > 100000 nM
Compound 4: no number, only a limit; the forecaster's own chance of this, stated with the estimate: 60%; the middle value lies on the limit itself.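

In this assay compound 4 gives > 100000 nM, which is a limit and not a number. Compound 3 also carries only a limit, so no step can be read between compound 3 and compound 4. The series stands as follows: the limit of > 100000 nM in this assay, at which 3 of the 4 values shown sit. The compounds shown leave open whether 3,4-difluorophenyl in place of 2-methoxyphenyl changes the value in this assay at all.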